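Ester alkyl group variation: compounds 1 to 4

The compounds below may be only part of what the source reports. "The series", "measured", "known", "first", "only" and "open" are said of these compounds alone.

Measured so far:
compound 1 `CCOC(=O)C1=CCCCC1S(=O)(=O)Cc1ccc(F)cc1Cl`: 10 nM; 10000 nM; 5.7 nM (3 entries)
compound 2 `COC(=O)C1=CCCCC1S(=O)(=O)Cc1ccc(F)cc1Cl`: 99 nM
compound 3 `CC(C)OC(=O)C1=CCCCC1S(=O)(=O)Cc1ccc(F)cc1Cl`: 100 nM

The read-out throughout is a functional assay on RAW264.7 cells (Mus musculus), read by fluorescence; on this read-out lower numbers stand for stronger inhibition and higher numbers for weaker inhibition. Compound 1 carries several entries, (the several entries of compound 1 in this assay, 10 nM; 10000 nM; 5.7 nM (3 entries)), spread so widely that no single number can be taken from them. Compound 2 gives 99 nM and compound 3 gives 100 nM; the step of a 1.0-fold higher number from compound 2 to compound 3 (0.00 log units; within the scatter) lies within the scatter. Compound 3 therefore stands highest of the two single numbers, with compound 2 alongside it within the scatter and compound 1 without a single number.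

Compound 4 `CCCCOC(=O)C1=CCCCC1S(=O)(=O)Cc1ccc(F)cc1Cl` differs from compound 3 by butyl in place of isopropyl on an oxygen next to a carbonyl group. Among the measured compounds shown here, the only measured step of the same kind, on the oxygen next to the carbonyl group, is a 1.0-fold higher number from compound 2 to compound 3 (0.00 log units; within the scatter), within the scatter; the entries of compound 1, (the several entries of compound 1 in this assay, 10 nM; 10000 nM; 5.7 nM (3 entries)), are too spread to fix a direction. The step expected in this assay is no change at the digits printed from compound 3 to compound 4 (within the scatter), none beyond the scatter. Compound 4 is therefore expected near 100 nM, with a range from 20 nM to 600 nM.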

Compound 4, half-maximal inhibitory concentration: 103 nM
For compound 4 the middle estimate is 1.0-fold (0.01 log units) below the measured one; low and high end bracket the measured number.
By their numbers in this assay, from the lowest: compounds 2, 3 and 4 (each within the scatter of the next).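

In this assay, butyl on the oxygen next to a carbonyl group reads the same as isopropyl and methyl, with no step beyond the scatter: a 1.0-fold higher number from compound 3 to compound 4 (0.01 log units; within the scatter), and a 1.0-fold higher number from compound 2 to compound 4 (0.02 log units; within the scatter). The earlier pair covered only methyl and isopropyl, so compound 4 extends this flat reading to a third group, and it now holds across compounds 2, 3 and 4. Compound 1 cannot be placed within that reading: the several entries of compound 1 in this assay, 10 nM; 10000 nM; 5.7 nM (3 entries)

Going by these compounds, whether the ester itself is needed stays open: a carboxylic acid or an amide in its place would test that, and a chain longer than butyl or a benzyl ester would show how far the flat reading extends. Also open, on these data alone, is which entry of compound 1 holds, and with it whether its ester departs from those of compounds 2, 3 and 4.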